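Cyclohexyl for 4-methoxyphenyl on the ring amide nitrogen

This account rests on a few compounds, and the source may have more. Where it says the series, first, only, none or still open, it means among the compounds named here.

Four compounds share a fused two-ring core holding an amide-type nitrogen in a ring; they differ in the group on that nitrogen and elsewhere in the molecule. Compound 1 `O=C1COc2ccc(-c3cnc4ccccc4c3)cc2N1C1CCCCC1` and compound 2 `COc1ccc(N2C(=O)COc3ccc(-c4cnc5ccccc5c4)cc32)cc1` are alike apart from that nitrogen substituent; how the core of compound 3 `COc1ccc(N2C(=O)COc3ccc(-c4cccc(NS(=O)(=O)c5ccc(F)cc5)c4)cc32)cc1` differs from that of compound 2 is not broken down here. Compound 4 `O=C1COc2ccc(-c3cccc(NS(=O)(=O)c4ccc(F)cc4)c3)cc2N1C1CCCCC1` is not yet measured.

In a functional assay on A549 cells (Homo sapiens) for antiproliferative activity, read by MTT assay, with a stated time of 72 h (on this read-out lower numbers stand for stronger inhibition and higher numbers for weaker inhibition), compound 2 reaches only the limit of the assay, > 40000 nM, not a number. Compound 1 likewise gives only a limit, > 40000 nM. The step that the two limits leave unreadable from compound 2 to compound 1 therefore cannot be read, since the limit of > 40000 nM in this assay, at which 2 of the 3 values shown sit, is where both sit. The change made there is cyclohexyl in place of 4-methoxyphenyl on an amide-type nitrogen in a ring. Among the compounds with values here, compound 3 is the one compound with a number: in this assay compound 3 gives 38200 nM.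

The change from compound 3 to compound 4 is the same: cyclohexyl in place of 4-methoxyphenyl on an amide-type nitrogen in a ring. Its size is not known from the measured pair. With compound 3 at 38200 nM and no readable precedent, the expected step of a 1.0-fold higher number from compound 3 to compound 4 (0.02 log units; within the scatter) is set near zero. For compound 4 the estimate is 40000 nM, with a range from 15000 nM to 120000 nM, and a real chance that only a limit is reported.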

Compound 4, half-maximal inhibitory concentration: 14500 nM
Compound 4: the middle estimate sits 2.8-fold (0.44 log units) above what was measured; measured number below the stated range.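

In this assay, cyclohexyl in place of 4-methoxyphenyl on the amide-type nitrogen in the ring gives a 2.6-fold lower number from compound 3 to compound 4 (0.42 log units; beyond the scatter), so on this core the change goes with a modest gain and does not cost activity. On the other core the same change cannot be read, since the step from compound 2 to compound 1 has a limit of the assay at both ends and no number at either: the limit of > 40000 nM in this assay, at which 2 of the 4 values shown sit. Whether the change carries from one core to another therefore remains untested, as a single readable pair gives its direction and size on one core only and does not show why the number moves.

The compounds shown leave open whether this gain is specific to cyclohexyl or would also appear with other groups on that nitrogen, such as cyclopentyl, a longer alkyl chain or a chain ending in an amine. They also leave open whether a carboxylic acid on such a group would move the number in either direction, and whether the step would keep its direction on a third core.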